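The compounds below may be only part of what the source reports. "The series", "measured", "known", "first", "only" and "open" are said of these compounds alone.

Measured in a functional assay on HCT-116 cells (Homo sapiens) for antiproliferative activity, read by MTT assay, with a stated time of 72 h; a lower number here means a stronger inhibitor, a higher number a weaker inhibitor:
- Compound 1 `O=C1COc2ccc(-c3cccc(NS(=O)(=O)c4ccc(F)cc4)c3)cc2N1`: > 40000 nM (a limit)
- Compound 2 `COc1cccc(N2C(=O)COc3ccc(-c4cccc(NS(=O)(=O)c5ccc(F)cc5)c4)cc32)c1`: > 40000 nM (a limit)

Compound 2 gives only a limit, > 40000 nM, not an exact number. It shares this position with compound 1, and the whole record so far is the limit of > 40000 nM in this assay, at which 2 of the 2 values shown sit.

Compound 3 `CC(C)N1C(=O)COc2ccc(-c3cccc(NS(=O)(=O)c4ccc(F)cc4)c3)cc21` keeps the core of compound 2 and changes one group: isopropyl in place of 3-methoxyphenyl on an amide-type nitrogen in a ring.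

Among the compounds with values here, one measured step bears on this change, since it alters the same nitrogen: a step that the two limits leave unreadable from compound 1 to compound 2. Its size cannot be read, so it offers no measured effect to carry over to compound 3. Hydrogen and 3-methoxyphenyl on that nitrogen both ended at the limit, and isopropyl is a different group from either, so a measurable value remains possible. Even so, the most reasonable expectation in this assay is no step beyond the scatter, in either direction.

The expected change is a number no higher from compound 2 to compound 3 (the limit leaves the size open). The estimated value for compound 3 is 40000 nM, with an expected range from 12000 nM to 80000 nM.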

Compound 3, half-maximal inhibitory concentration: 22600 nM
Estimate against measurement, compound 3: 1.8-fold (0.25 log units) above; the measured number falls inside the stated range.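

In this assay, isopropyl is the first group on this amide-type nitrogen to give an exact number, which neither hydrogen nor 3-methoxyphenyl did, and the other two compounds remain at the assay's limit: the limit of > 40000 nM in this assay, at which 2 of the 3 values shown sit.

Replacing 3-methoxyphenyl with isopropyl gives an at least 1.7-fold lower number from compound 2 to compound 3 (0.24 log units; that floor lies within the scatter), and replacing hydrogen with isopropyl gives an at least 1.7-fold lower number from compound 1 to compound 3 (0.24 log units; that floor lies within the scatter). Going by these compounds, both steps are floors set by a limit, so their true sizes remain open, and the step between the two compounds at the limit cannot be read at all.

The compounds shown leave open whether a measurable number at this nitrogen is particular to isopropyl or also appears with a methyl, an ethyl or a longer chain such as n-butyl. They also leave open what a chain ending in an amine or a carboxylic acid would give at this position, and whether any group here could move the number clearly beyond the usual scatter of the assay.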